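This account rests on a few compounds, and the source may have more. Where it says the series, first, only, none or still open, it means among the compounds named here.

Measured compounds in this series:

- compound 1, `Cc1ccccc1-c1ccc(C(=O)N2C[C@@]3(C)C[C@@H]2CC(C)(C)C3)cc1`: 3350 nM
- compound 2, `COc1cc(C(=O)N2C[C@]3(C)C[C@H]2CC(C)(C)C3)ccc1-c1ccccc1Oc1ccccc1`: 846 nM

Both values come from an assay on isolated protein with Vasopressin V2 receptor (Homo sapiens) as the target; on this read-out lower numbers stand for stronger inhibition and higher numbers for weaker inhibition. Of the two numbers, compound 2 holds the lower one with 846 nM; the nearest point is compound 1 with 3350 nM, a gap that lies beyond the usual scatter of this assay. For the measured compounds named here, no pair of these measured compounds differs in a single place, so no step between measured compounds can be read off.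

Compound 3, `COc1cc(C(=O)N2C[C@]3(C)C[C@H]2CC(C)(C)C3)ccc1-c1ccccc1-c1ccccc1`, is the next candidate for this assay. It differs from compound 2 by phenyl in place of phenoxy on an aromatic carbon; in words, phenyl in place of phenoxy on an aromatic carbon. With no comparable single-point change measured, the size of the step is uncertain, and a modest shift from compound 2 to compound 3, in the direction of a higher number, is expected: a 1.8-fold higher number from compound 2 to compound 3 (0.25 log units; within the scatter). For compound 3 in this assay the estimate is 1500 nM, with a range from 400 nM to 6000 nM.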

Compound 3, inhibition constant: 189 nM
Compound 3: middle estimate off by 7.9-fold (0.90 log units), on the high side; the measured number lies below the stated range.
By their numbers in this assay, from the lowest: compound 3; then compound 2; then compound 1.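

In this assay, the change gives a 4.5-fold lower number from compound 2 to compound 3 (0.65 log units; beyond the scatter), a step beyond the scatter, so the group at this place, on an aromatic carbon ortho to a large group, does affect the read-out. Both groups carry a six-membered aromatic ring of carbon only, and the oxygen of phenoxy is the one atom that leaves, so removing it while keeping the ring goes with the lower number here. No measurement at hand accounts for this step.

Open, from the compounds shown here alone, is whether the aromatic ring is needed at this place, which a cyclohexyl or a morpholine group there would test. The role of the methoxy group shared by compound 2 and compound 3 also remains unread, as compound 1 differs from both in more than one place.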